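A few compounds are considered here, and "the series" means these few. Any claim that something is new, unique, unknown or untested is made for them only; others in the source may bear on it.

Measured in a functional assay on cells (Homo sapiens) for cytotoxicity, read by MTT assay, with a stated time of 72 h; on this read-out lower numbers stand for stronger inhibition and higher numbers for weaker inhibition:
compound 1 `Cc1ccc(C)c(COc2cc(NC(=O)c3ccccc3)ccc2N(C)S(C)(=O)=O)c1` gives 4680 nM
compound 2 `Cc1cccc(COc2cc(NC(=O)c3ccccc3)ccc2N(C)S(C)(=O)=O)c1` gives 16100 nM
compound 3 `Cc1cccc(C)c1COc1cc(NC(=O)C2CCCCC2)ccc1N(C)S(C)(=O)=O` gives 39400 nM

Compound 3 carries the highest number of the three. The difference between the core of compound 3 and that of compound 2 is not broken down here. Between compound 2 and compound 1 the change is methyl in place of hydrogen on an aromatic carbon and it gave a 3.4-fold lower number from compound 2 to compound 1 (0.54 log units; beyond the scatter).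

Compound 4 `Cc1cc(C)c(COc2cc(NC(=O)C3CCCCC3)ccc2N(C)S(C)(=O)=O)c(C)c1` is unmeasured; it differs from compound 3 by methyl in place of hydrogen on an aromatic carbon. This is the same kind of change as from compound 2 to compound 1, but the surroundings differ: there the entering methyl sat ortho to a large group and para to a methyl group, here it sits meta to two methyl groups and para to a large group. Going by the values given here, a smaller step is expected, a 2.0-fold lower number from compound 3 to compound 4 (0.29 log units; within the scatter), resting on the single prior step a 3.4-fold lower number from compound 2 to compound 1 (0.54 log units; beyond the scatter) and on compound 3 at 39400 nM. The value expected for compound 4 in this assay is 20000 nM, within 8000 nM to 60000 nM.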

Compound 4, half-maximal inhibitory concentration: 18500 nM
For compound 4 the middle estimate is 1.1-fold (0.03 log units) above the measured one, within the range that was stated.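

Going from 2,6-dimethylbenzyl to 2,4,6-trimethylbenzyl gives a 2.1-fold lower number from compound 3 to compound 4 (0.33 log units; beyond the scatter) in this assay. Methyl in place of hydrogen on an aromatic carbon lowers the number on both cores, and the two steps do not differ in size beyond the scatter: the same change on two cores in this assay, a 3.4-fold lower number (0.54 log units; beyond the scatter) from compound 2 to compound 1 and a 2.1-fold lower number (0.33 log units; beyond the scatter) from compound 3 to compound 4, 1.6-fold (0.21 log units) apart, within the scatter of two such steps

Going by these compounds alone, these are only two pairs, with the entering methyl in different surroundings, so they show that the change carries across these two cores but not that it would hold on other cores, or why the number falls.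

Still open, as far as these compounds go, is whether methoxy, chlorine or a carboxylic acid in that place would move the number as methyl does. Also open, from the compounds shown here alone, is what an amine or a longer chain on the amide carbonyl would give.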